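Methoxy in Place of Fluoro on a Shared Core

A few compounds are considered here, and "the series" means these few. Any claim that something is new, unique, unknown or untested is made for them only; others in the source may bear on it.

Of the compounds shown here, three built on one shared core have been measured in a functional assay on MCF7 cells (Homo sapiens) for cytotoxicity, read by MTT assay, with a stated time of 72 h; a higher number here means a weaker inhibitor, a lower number a stronger inhibitor. Compound 1 `COc1ccc(-c2ccc(C)n2-c2ccc(-c3nc4ccccc4s3)cc2)cc1` gives 3260 nM in this assay. Among the compounds with values here, compound 2 `COc1ccc(-c2ccc(C)n2-c2ccc(-c3nc4ccc(F)cc4s3)cc2)cc1` gives 2550 nM in this assay, and the only single-point step among the measured compounds, a 1.3-fold lower number from compound 1 to compound 2 (0.11 log units; within the scatter), lies within the scatter. Compound 3 `COc1ccc2nc(-c3ccc(-n4c(C)ccc4-c4ccc(F)cc4)cc3)sc2c1` gives 2800 nM in this assay; its number is nearest to that of compound 2 and furthest from that of compound 1, yet all three values sit within the scatter of one another, so no ranking among them can be read.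

Compound 4 `COc1ccc(-c2ccc(C)n2-c2ccc(-c3nc4ccc(OC)cc4s3)cc2)cc1` is the next compound. It differs from compound 3 by methoxy in place of fluoro on an aromatic carbon. Within the data shown here, no measured pair shows this exact exchange. Among the measured compounds shown here, the one measured step, fluoro in place of hydrogen on an aromatic carbon, bears on it only loosely and was itself within the scatter. With the three measured values so close together and no step beyond the scatter anywhere in the set, the expectation for the step of a 1.0-fold lower number from compound 3 to compound 4 (0.02 log units; within the scatter) is one that stays within the scatter, with no clear direction. Compound 4 is therefore expected to give about 2700 nM in this assay, with a range from 1300 nM to 5500 nM.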

Compound 4, half-maximal inhibitory concentration: 4830 nM
Compound 4: the middle estimate sits 1.8-fold (0.25 log units) below what was measured; the range from low to high includes it.
By their numbers in this assay, from the lowest: compounds 2, 3, 1 and 4 (each within the scatter of the next).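

Compound 4 adds methoxy to the picture, and in this assay the change from 4-fluorophenyl to 4-methoxyphenyl, on an aromatic carbon para to a large group, gives a 1.7-fold higher number from compound 3 to compound 4 (0.24 log units; within the scatter). The same exchange of fluoro for methoxy at a different aromatic carbon gives a 1.9-fold higher number from compound 2 to compound 4 (0.28 log units; within the scatter), and methoxy in place of hydrogen there gives a 1.5-fold higher number from compound 1 to compound 4 (0.17 log units; within the scatter), so the earlier single step of fluoro for hydrogen is now joined by methoxy steps at two different aromatic carbons, none of them beyond the scatter. A group with an oxygen and a carbon in place of a lone fluorine therefore leaves the number within the scatter at both places, and nothing available explains these values.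

As far as these compounds go, whether an amine, a carboxylic acid or a longer chain such as butoxy at either place would move the number beyond the scatter stays open. Also open, from the compounds shown here alone, is whether these small steps would look the same in a cell line other than the one used here.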